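This account rests on a few compounds, and the source may have more. Where it says the series, first, only, none or still open, it means among the compounds named here.

Among the compounds with values here, compound 1 `COc1cnc(-c2ccccn2)nc1N1CCCCCC1` gives 690 nM in a functional assay on RAW264.7 cells (Mus musculus), with a stated time of 3 days (a lower number here means a stronger inhibitor, a higher number a weaker inhibitor), the highest of the three numbers so far. Compound 3 `COc1cnc(-c2ccccn2)nc1NCc1ccccc1Cl` gives 520 nM in this assay, within the scatter of compound 1. Compound 2 `COc1cnc(-c2ccccn2)nc1NCc1ccccc1F` gives 130 nM in this assay, beyond the scatter from compound 1. Within the data shown here, the one measured single-point step, a 4.0-fold higher number from compound 2 to compound 3 (0.60 log units; beyond the scatter), concerns the aromatic halogen and does not bear on the change considered here. Compound 4 `COc1cnc(-c2ccccn2)nc1NC1CCCC1` differs from compound 1 by cyclopentylamino in place of azepan-1-yl on an aromatic carbon. Among the measured compounds shown here, no measured step covers a change of this kind; compound 2, which like compound 4 carries one hydrogen-bond donor in the group on the core, gives a lower number than compound 1, while compound 3 is within the scatter of compound 1. A step of a 2.0-fold lower number from compound 1 to compound 4 (0.29 log units; within the scatter) toward a lower number is therefore expected, on a thin basis. Compound 4 is expected to give 350 nM in this assay, within 120 nM to 1000 nM.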

Compound 4, half-maximal inhibitory concentration: 570 nM
The estimate for compound 4 lay 1.6-fold (0.21 log units) below the measured number, within the range that was stated.
By their numbers in this assay, from the lowest: compound 2; then compounds 3, 4 and 1 (each within the scatter of the next).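

In this assay, cyclopentylamino in place of azepan-1-yl gives a 1.2-fold lower number from compound 1 to compound 4 (0.08 log units; within the scatter), so this position tolerates the exchange without a change beyond the scatter. The exchange alters the ring and adds a hydrogen-bond donor at once, and together these leave the number unmoved, so a donor on this group is not enough on its own to shift it. No evidence on the reason for this is available.

Still open, on these data alone, is how an open-chain group such as diethylamino, or a morpholin-4-yl ring, would read at this position. Also open, as far as these compounds go, is whether piperidin-1-yl would match azepan-1-yl.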